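The source may hold more compounds than are shown below. What is called first, only, known or untested is meant among the compounds shown, and "the series" means these compounds.

Compound 1 `N#C/C(=C\c1ccc(Cl)cc1)C(=O)c1ccc[nH]1`: 43000 nM
Compound 2 `N#C/C(=C\c1c[nH]c2ccccc12)C(=O)c1c[nH]c2ccccc12`: 7600 nM
Compound 3 `COc1ccc(CNC(=O)/C(C#N)=C/c2ccc[nH]2)cc1`: > 50000 nM

All three compounds were tested in a functional assay on NCI-H460 cells (Homo sapiens) for inhibition, read by MTT assay, with a stated time of 72 h; on this read-out higher numbers stand for weaker inhibition of growth and lower numbers for stronger inhibition of growth. Compound 1 gives 43000 nM, and compound 2 gives a lower value, 7600 nM; these two compounds differ in several places at once, so only the two numbers themselves can be compared. The value for compound 3 is a limit of this assay, not a measured number: > 50000 nM. Compound 3 sits at the weak end of the numbers shown, at the limit of > 50000 nM in this assay, at which 1 of the 3 values shown sits, so its true potency is known only to be weaker than that point.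

Compound 4 `COc1ccc(CNC(=O)/C(C#N)=C/c2ccc(Cl)o2)cc1` keeps the amide side of compound 3 and changes the aromatic ring on the chain: 5-chlorofuran-2-yl in place of 1H-pyrrol-2-yl on a double-bonded chain carbon bound to a double-bonded chain carbon. Among the measured compounds shown here, no pair of measured compounds differs in exactly this way, so there is no measured step to lean on. Since compound 3 shows no measurable inhibition of growth within the tested range, the expectation for compound 4 is that it will again fall at or near that weak end, with a step of a number no higher from compound 3 to compound 4 (the limit leaves the size open) expected to stay within the scatter or to remain beyond the measurable range. The estimated value for compound 4 is 50000 nM, in a range from 15000 nM to 150000 nM.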

Compound 4, concentration for 50% growth inhibition: 15000 nM
Compound 4: the middle estimate sits 3.3-fold (0.52 log units) above what was measured, within the range that was stated.
By their numbers in this assay, from the lowest: compounds 2 and 4 (each within the scatter of the next); then compound 1. At a limit, above all of these: compound 3.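

In this assay, putting 5-chlorofuran-2-yl in place of 1H-pyrrol-2-yl on a double-bonded chain carbon bound to a double-bonded chain carbon gives an at least 3.3-fold lower number from compound 3 to compound 4 (0.52 log units; beyond the scatter). Among the compounds shown here, with the amide side held the same, this is the first evidence here that the ring at this position matters on its own, since the earlier compounds differ in several places at once and could not isolate any single change. The value for compound 3 is a limit and not a number, so the true size of the step stays open and it can only be read as a minimum: the limit of > 50000 nM in this assay, at which 1 of the 4 values shown sits.

The swap changes several things together, counted as the loss of a hydrogen-bond donor, the gain of a hydrogen-bond acceptor and the arrival of a chlorine, so the compounds shown leave open which of these carries the step, a question that a furan-2-yl ring without chlorine or a 5-chloro-1H-pyrrol-2-yl ring could help to settle. They also leave open whether another atom or group in the place of that chlorine, such as bromine or a methyl group, would give a lower or a higher number.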